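The source may report more compounds than this note shows. Statements on the series, on what has been measured and on what is new or still open speak of the compounds shown alone.

The study concerns a small set of compounds sharing one core and measured in a functional assay on L5178Y cells (Mus musculus); a lower number here means a less potent compound, a higher number a more potent compound, by a factor of ten per unit of this negative logarithm. Compound 1 `CC1(C)N=C(N)N=C(N)N1c1cccc(C(O)c2ccccc2)c1` gives 4.17 in this assay. For the measured compounds named here, compound 2 `CC(=O)c1cccc(N2C(N)=NC(N)=NC2(C)C)c1` gives 4.56 in this assay, and this is the higher of the two numbers so far; the only measured step, a number 0.39 log units higher from compound 1 to compound 2 (beyond the scatter), separates compound 2 from compound 1.

The next compound, compound 3 `CC1(C)N=C(N)N=C(N)N1c1cccc(S(N)(=O)=O)c1`, has not been measured in this assay. It differs from compound 2 in one place: sulfamoyl in place of acetyl on an aromatic carbon. Going by the values given here, no measured step involves a sulfamoyl group, so the one step recorded, a number 0.39 log units higher from compound 1 to compound 2 (beyond the scatter), bears on the present change only indirectly, as a sign that groups at this position have so far moved the number by a modest amount. Because compound 2 gives 4.56, the expectation for compound 3 in this assay is a step of about a number 0.06 log units lower from compound 2 to compound 3 (within the scatter), which lies within the scatter. The estimate for compound 3 is therefore 4.5, with a range from 4 to 5.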

Compound 3, logarithm of the reciprocal of the active concentration, log(1/C): 3.13
Compound 3: the middle estimate sits 1.37 log units above what was measured; the whole stated range lies above it.
By their numbers in this assay, from the lowest: compound 3; then compound 1; then compound 2.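

In this assay, for the compounds shown here, this place on the aromatic ring, meta to a large group, proves far more sensitive than the one earlier step suggested: sulfamoyl in place of acetyl gives a number 1.43 log units lower from compound 2 to compound 3 (beyond the scatter), a large step where the earlier one was modest. The loss is not tied to the comparison with acetyl alone, since sulfamoyl in place of hydroxy(phenyl)methyl gives a number 1.04 log units lower from compound 1 to compound 3 (beyond the scatter), again large and beyond the scatter. Of the three groups, sulfamoyl therefore gives the lowest number, while the two carbon-linked groups both stand clearly above it. Nothing available here explains this drop.

On these data alone, whether a methylsulfonyl group, a carboxamide or a carboxylic acid at this place would stay near compound 2 or fall towards compound 3 remains open. Also open, as far as these compounds go, is whether the low number follows the sulfur of the sulfamoyl group or its nitrogen, and whether a longer ketone chain in place of acetyl would hold the number of compound 2 at 4.56 or change it.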